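Hydroxy on the phenyl group of compound 2

The compounds below may be only part of what the source reports. "The series", "measured", "known", "first", "only" and "open" are said of these compounds alone.

Measured values in a physicochemical assay for solubility, read by spectrophotometry, in phosphate buffer, with a stated time of 18 h, at pH 7.4 (a lower number here means a less soluble compound, a higher number a more soluble compound), so far:
- compound 1 `CCc1ccc(-c2nc3c(c(C)nn3-c3ccccc3)c(-c3ccccc3C(F)(F)F)c2C#N)cc1` gives 11000 nM
- compound 2 `CCc1ccc(-c2nc3c(c(C)nn3-c3ccccc3)c(-c3ccccc3)c2C#N)cc1` gives 47000 nM

Compound 2 holds the higher of the two numbers at 47000 nM in this small set. Compound 3 `CCc1ccc(-c2nc3c(c(C)nn3-c3ccccc3)c(-c3cccc(O)c3)c2C#N)cc1` has hydroxy in place of hydrogen on an aromatic carbon of compound 2 with hydroxy in place of hydrogen on an aromatic carbon as the counted difference. Going by the values given here, one measured step bears on this. Hydrogen in place of trifluoromethyl on that same aromatic group gave a 4.3-fold higher number from compound 1 to compound 2 (0.63 log units; beyond the scatter) as the only size available for a change there. That step involves a different group, so it offers a rough scale and no direction. Among the compounds with values here, no hydroxy compound has been measured. A small rise is expected, possibly within the scatter and hardly larger than that modest step. For compound 3 the estimated value is 55000 nM with an expected range from 22000 nM to 120000 nM in this assay as the read-out. This estimate means an expected 1.2-fold higher number from compound 2 to compound 3 (0.07 log units; within the scatter) overall.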

Compound 3, solubility: 18000 nM
Beside the measured number, compound 3's estimate is 3.1-fold (0.49 log units) above it, and the stated range ends above it.
By their numbers in this assay, from the lowest: compounds 1 and 3 (each within the scatter of the next); then compound 2.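

With this assay as the read-out, hydroxy in place of hydrogen on the phenyl group gives a 2.6-fold lower number from compound 2 to compound 3 (0.42 log units; beyond the scatter), so this first change on compound 2 that adds a group to that phenyl lowers the number. Compounds 1 and 3 both now stand below compound 2, while the two substituted phenyl groups cannot be separated: 3-hydroxyphenyl in place of 2-(trifluoromethyl)phenyl gives a 1.6-fold higher number from compound 1 to compound 3 (0.21 log units; within the scatter). Nothing available accounts for this result.

Each substituted compound carries a different group at a different place on the phenyl, so the effect of the group and that of its place remain tangled. From the compounds shown here alone, whether an amine or a carboxylic acid on this phenyl would also stand below compound 2 remains open.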